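The source may hold more compounds than are shown below. What is called first, only, known or untested is meant among the compounds shown, and "the series" means these compounds.

The three measured compounds share one core and differ only in the group carried on a carbonyl carbon. Compound 1 `Cc1cn(C2CC(N=[N+]=[N-])C(COC(=O)NCCCO)O2)c(=O)[nH]c1=O` is the reference point; in a physicochemical assay for lipophilicity (on this read-out lower numbers stand for lower lipophilicity and higher numbers for higher lipophilicity), compound 1 gives -1.24, the lowest of the three numbers recorded. Compound 2 `Cc1cn(C2CC(N=[N+]=[N-])C(COC(=O)NCCCN)O2)c(=O)[nH]c1=O` gives -1.19, and the step of a number 0.05 log units higher from compound 1 to compound 2 (within the scatter). Compound 3 `Cc1cn(C2CC(N=[N+]=[N-])C(COC(=O)CCCN)O2)c(=O)[nH]c1=O` gives -0.9, so that a number 0.34 log units higher from compound 1 to compound 3 (beyond the scatter), while a number 0.29 log units higher from compound 2 to compound 3 (within the scatter).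

Compound 4 `Cc1cn(C2CC(N=[N+]=[N-])C(COC(=O)OCCCC(=O)O)O2)c(=O)[nH]c1=O` has not yet been measured. Relative to compound 1 the change is 3-carboxypropoxy in place of (3-hydroxypropyl)amino on a carbonyl carbon. Among the compounds with values here, none of the measured steps reproduces this change. The step to compound 2 puts amino in place of hydroxy on the chain and stays within the scatter; the step to compound 3 puts 3-aminopropyl in place of (3-hydroxypropyl)amino on the carbonyl carbon and gives only a modest rise. The change to compound 4 touches both the chain end and the atom on the carbonyl carbon, and the measured data offer no direct guide to its direction. The step from compound 1 is therefore expected to be small, a number 0.16 log units lower from compound 1 to compound 4 (within the scatter), with a wide range. Compound 4 is estimated at -1.4, between -2.2 and -0.6.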

Compound 4, partition coefficient: -0.55
The estimate for compound 4 lay 0.85 log units below the measured number, and the stated range ends below it.
By their numbers in this assay, from the lowest: compounds 1, 2 and 3 (each within the scatter of the next, the first and the last beyond it); then compound 4.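

In this assay, the group on this carbonyl carbon now stands apart from all three earlier ones: the change to 3-carboxypropoxy gives a number 0.69 log units higher from compound 1 to compound 4 (beyond the scatter) and, from the amine-ended carbamate, a number 0.64 log units higher from compound 2 to compound 4 (beyond the scatter) even though compound 1 and compound 2 themselves could not be told apart. Within the data shown here, compound 3 was the only earlier compound clear of compound 1, and the series extends past it as well, with a number 0.35 log units higher from compound 3 to compound 4 (beyond the scatter) placing compound 4 at the top of the four numbers. The position therefore allows a wider spread than the earlier compounds showed, and a chain ending in a carboxylic acid and joined through oxygen sits at its upper end, but no measurement offered here explains the rise.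

Compound 4 differs from compound 1 both in the atom on the carbonyl carbon and in the end of the chain, so the two changes cannot be separated. A 3-hydroxypropoxy group or a (3-carboxypropyl)amino group would take them one at a time, and a longer chain ending in a carboxylic acid would show whether chain length matters here.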